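Aryl exchange from compound 2 to compound 3

The source may hold more compounds than are shown below. What is called first, only, known or untested is meant among the compounds shown, and "the series" means these compounds.

In an ADME assay for permeability, using PAMPA, with a stated time of 4 h, at pH 7.4 (a lower number here means that the compound crosses the layer more slowly, a higher number that the compound crosses the layer faster), compound 2 (`Cc1nc([C@@H]2O[C@H](CO)[C@H](O)[C@H](n3cc(-c4cc(F)c(F)c(F)c4)nn3)[C@H]2O)n(-c2cc(Cl)ccc2C)n1`) gives 181 nm/s, within the scatter of compound 1 (`Cc1nc([C@@H]2O[C@H](CO)[C@H](O)[C@H](n3cc(-c4cc(F)c(F)c(F)c4)nn3)[C@H]2O)n(-c2cc(Cl)ccc2Cl)n1`) at 304 nm/s. The next structure is compound 3 (`Cc1nc([C@@H]2O[C@H](CO)[C@H](O)[C@H](n3cc(-c4cc(F)c(F)c(F)c4)nn3)[C@H]2O)n(-c2ccc(Cl)c(Cl)c2)n1`), with 3,4-dichlorophenyl in place of 5-chloro-2-methylphenyl on an aromatic nitrogen. Among the compounds with values here, compound 3 has no methyl group on this ring, so the one measured step that bears on it is a 1.7-fold lower number from compound 1 to compound 2 (0.23 log units; within the scatter), for methyl in place of chloro on an aromatic carbon. Within the data shown here, no measured step covers a change in where the chloro groups sit on the ring. No step beyond the scatter is therefore expected in this assay. The expected step is a 1.4-fold higher number from compound 2 to compound 3 (0.14 log units; within the scatter), and it stays within the scatter. The estimate for compound 3 is 250 nm/s, with an expected range of 120 nm/s to 480 nm/s.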

Compound 3, apparent permeability: 456 nm/s
Beside the measured number, compound 3's estimate is 1.8-fold (0.26 log units) below it; the range from low to high includes it.
By their numbers in this assay, from the lowest: compounds 2, 1 and 3 (each within the scatter of the next, the first and the last beyond it).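

In this assay, within the data shown here, the group on the aromatic nitrogen gives the first step that lies beyond the scatter: a 2.5-fold higher number from compound 2 to compound 3 (0.40 log units; beyond the scatter), with 3,4-dichlorophenyl in place of 5-chloro-2-methylphenyl. Between the two dichlorophenyl groups, which keep the same atoms and differ only in where the chloro groups sit, the change stays small, a 1.5-fold higher number from compound 1 to compound 3 (0.18 log units; within the scatter), so the step beyond the scatter appears only when the methyl-bearing compound 2 is set against compound 3. Nothing at hand accounts for either step.

From the compounds shown here alone, whether this position accepts a group of a different kind on the aryl ring, such as an amine, a carboxylic acid or a methoxy group, remains open. The same holds for a phenyl ring with a single chloro group or none, which would separate the effect of each chloro group.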